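Amide substituent changes on the shared core

The source may report more compounds than this note shows. Statements on the series, on what has been measured and on what is new or still open speak of the compounds shown alone.

The shared core is carried by compound 1 `CC(C)(C)c1ccc(C(=O)N2CCC3(CC2)C(=O)N(CC(=O)NCN)CN3c2ccccc2)cc1` and compound 2 `CC(C)(C)c1ccc(C(=O)N2CCC3(CC2)C(=O)N(CC(=O)NCCCCNS(C)(=O)=O)CN3c2ccccc2)cc1`. Going by the values given here, in an assay on HEK293 cells for displacement of a labelled ligand from NPC1-like intracellular cholesterol transporter 1 (Homo sapiens) (on this read-out higher numbers stand for weaker inhibition and lower numbers for stronger inhibition), compound 1 gives 26500 nM, and compound 2 gives 4500 nM, so compound 2 stands at the lowest of the two numbers so far, its only neighbour being compound 1 with a 5.9-fold lower number from compound 1 to compound 2 (0.77 log units; beyond the scatter). Compound 3 `CC(C)(C)c1ccc(C(=O)N2CCC3(CC2)C(=O)N(CC(=O)N2CCCCC2CO)CN3c2ccccc2)cc1` keeps this core and differs from compound 2 by 2-(hydroxymethyl)piperidin-1-yl in place of (4-(methanesulfonamido)butyl)amino on a carbonyl carbon. Among the compounds with values here, only one measured step bears on this change, a 5.9-fold lower number from compound 1 to compound 2 (0.77 log units; beyond the scatter), which altered the same group on the carbonyl carbon and was modest. Compound 3 gives up the sulfonamide-bearing chain that came in with that step, so a moderate rise relative to compound 2 is expected, without a return to the number of compound 1. For compound 3 the expected step is a 2.0-fold higher number from compound 2 to compound 3 (0.30 log units; within the scatter). Compound 3 is therefore estimated at 9000 nM in this assay, within 3000 nM to 30000 nM.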

Compound 3, half-maximal inhibitory concentration: 11800 nM
For compound 3 the middle estimate is 1.3-fold (0.12 log units) below the measured one; the range from low to high includes it.
By their numbers in this assay, from the lowest: compound 2; then compound 3; then compound 1.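

Replacing (4-(methanesulfonamido)butyl)amino with 2-(hydroxymethyl)piperidin-1-yl on the carbonyl carbon raises the number in this assay (a 2.6-fold higher number from compound 2 to compound 3 (0.42 log units; beyond the scatter)), while the same group still lowers it relative to (aminomethyl)amino (a 2.2-fold lower number from compound 1 to compound 3 (0.35 log units; beyond the scatter)). The three compounds thus take three separate levels, and a group with a six-membered non-aromatic ring and no methanesulfonamido unit can still give a lower number than compound 1 does. Nothing on hand accounts for these differences.

Open, on these data alone, is whether the standing of compound 2 goes with the methanesulfonamido unit or with the butyl chain, which a plain butylamino group would help to separate. Also open, as far as these compounds go, is what the hydroxymethyl contributes in compound 3, a question for plain piperidin-1-yl.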